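Replacing benzoylmethyl on compound 3 to reach compound 4

A few compounds are considered here, and "the series" means these few. Any claim that something is new, unique, unknown or untested is made for them only; others in the source may bear on it.

- compound 1 `CC(C)OC(=O)COC(=O)c1ccc([N+](=O)[O-])o1` gives > 100000 nM as a limit of the assay
- compound 2 `CCC(C)(C)NC(=O)COC(=O)c1ccc([N+](=O)[O-])o1` gives > 100000 nM as a limit of the assay
- compound 3 `CC(C)(C)N(CCC(=O)c1ccccc1)C(=O)COC(=O)c1ccc([N+](=O)[O-])o1` is reported as "not active" (no number reported) without a figure

In an ADME assay on MT4 cells (Homo sapiens) for cytotoxicity, read by MTT assay, with a stated time of 3 days (a higher number here means that more compound is tolerated, a lower number that less compound is tolerated), compound 3 therefore stands without a number, and the entries for the other two compounds are limits rather than numbers. Compound 4 `CC(C)(C)N(Cc1ccc(C(F)(F)F)cc1)C(=O)COC(=O)c1ccc([N+](=O)[O-])o1` keeps the rest of compound 3 and puts 4-(trifluoromethyl)phenyl in place of benzoylmethyl on a saturated chain carbon bound to an amide-type nitrogen. Going by the values given here, only one measured step exists, a step that the two limits leave unreadable from compound 1 to compound 2, and it concerns another part of the molecule, so it offers no size to carry over. What remains is the limit of > 100000 nM in this assay, at which 2 of the 3 values shown sit, a pattern that covers only compound 1 and compound 2, since compound 3 has no figure. The expectation leans on compound 2, which gives > 100000 nM as a limit of the assay. No step beyond the scatter is therefore expected in this assay for this change, and the data suggest no direction for one. For compound 4 the estimated value is 80000 nM, with an expected range from 25000 nM to 100000 nM, and a report as a limit is quite possible.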

Compound 4, half-maximal cytotoxic concentration: 71000 nM
Beside the measured number, compound 4's estimate is 1.1-fold (0.05 log units) above it, within the range that was stated.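

Going by these compounds alone, compound 3 is reported without a figure in this assay, whereas compound 4 gives 71000 nM, and no step between compound 3 and compound 4 can be read. The compounds shown leave open what size of change, if any, goes with 4-(trifluoromethyl)phenyl in place of benzoylmethyl on a saturated chain carbon bound to an amide-type nitrogen.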